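Swapping 2-hydroxyethyl for dimethylamino on a carbonyl carbon

A few compounds are considered here, and "the series" means these few. Any claim that something is new, unique, unknown or untested is made for them only; others in the source may bear on it.

Among the compounds with values here, in an ADME assay on microsomes from liver (Homo sapiens) for metabolic stability, with a stated time of 30 min (on this read-out lower numbers stand for a less stable compound and higher numbers for a more stable compound), compound 3 (`O=C(CCO)N[C@@H](CO)C(=O)O`) gives 96% and this is the only number available. Compound 1 (`O=C(O)[C@H](CO)NC(=O)N1CCCC1`) has the entry "not determined" (no result reported) here, and compound 2 (`COC(=O)C(=O)N[C@@H](CO)C(=O)O`) has the entry "not determined" (no result reported) as well, so neither offers a comparison. Compound 4 (`CN(C)C(=O)N[C@@H](CO)C(=O)O`) has yet to be measured. It differs from compound 3 in a single place (dimethylamino in place of 2-hydroxyethyl on a carbonyl carbon) on a carbonyl carbon. Within the data shown here, no measured step exists to guide a forecast, so the expectation rests on compound 3 at 96% and on this one change. An expected a number 6 percentage points lower from compound 3 to compound 4 (within the scatter) would stay within the usual scatter, with any drift more likely downward. Compound 4 is expected at 90% within an estimated range of 72% to 100% in repeat runs.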

Compound 4, percent of the compound remaining: 34%
Compound 4: middle estimate off by 56 percentage points, on the high side; the whole stated range lies above it.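

In this assay, this place on the carbonyl carbon proves sensitive: dimethylamino in place of 2-hydroxyethyl gives a number 62 percentage points lower from compound 3 to compound 4 (beyond the scatter), a step beyond the scatter. The size of the group does not obviously account for this, as each has 3 heavy atoms, no ring and no net charge, while the hydrogen-bond donors and acceptors each go from 1 to 0. No available measurement explains the drop.

From the compounds shown here alone, it remains open whether the missing hydroxyl or the incoming nitrogen matters more. A propyl chain or a methylamino group at this place would help separate the two.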